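This account rests on a few compounds, and the source may have more. Where it says the series, first, only, none or still open, it means among the compounds named here.

Compound 1 `Cc1cc(NC(=O)Cn2nnc(-c3ccccc3)n2)n(CC2CCCCC2)n1`: 176 nM
Compound 2 `Cc1cc(NC(=O)Cn2nnc(-c3cccnc3)n2)n(C2CCCCC2)n1`: 1930 nM

In an assay on HEK293 cells for activation of Kir3.1/Kir3.2 (Homo sapiens), read by thallium flux (on this read-out higher numbers stand for an effect only at larger amounts of compound and lower numbers for an effect already at smaller amounts), compound 2 gives 1930 nM, the highest of the two numbers shown; compound 1 gives 176 nM, a gap beyond the usual scatter, though the two compounds differ in more than one place. Compound 3 `Cc1cc(NC(=O)Cn2nnc(-c3cccc(F)c3)n2)n(C2CCCCC2)n1` is not yet measured. It differs from compound 2 by 3-fluorophenyl in place of pyridin-3-yl on an aromatic carbon. Compound 1, which has no pyridin-3-yl, gives 176 nM, so a drop beyond the scatter is expected for compound 3 in this assay. For compound 3 the estimated value is 400 nM, with a range of 120 nM to 1300 nM. The expected step is a 4.8-fold lower number from compound 2 to compound 3 (0.68 log units; beyond the scatter).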

Compound 3, half-maximal effective concentration: 81 nM
For compound 3 the middle estimate is 4.9-fold (0.69 log units) above the measured one, and the stated range ends above it.
By their numbers in this assay, from the lowest: compound 3; then compound 1; then compound 2.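

In this assay putting 3-fluorophenyl in place of pyridin-3-yl on the aromatic carbon gives a 24-fold lower number from compound 2 to compound 3 (1.38 log units; beyond the scatter) and this large step shows that activity at this position depends strongly on the ring it carries. The change removes a ring nitrogen and adds a fluorine together, so this one step cannot separate the two. No measurement here bears on the reason for the step.

Going by these compounds, whether the fluorine itself matters remains open, since plain phenyl has not been paired with the cyclohexyl group of compound 3 here. On these data alone, how 3-chlorophenyl or 3-methoxyphenyl would compare also remains open.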